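This account rests on a few compounds, and the source may have more. Where it says the series, first, only, none or still open, it means among the compounds named here.

Compound 1 `CCCCCCCCNc1ccc(C(=O)O)cc1S(=O)(=O)NC` and compound 2 `CCCCCCNc1ccc(C(=O)O)cc1S(=O)(=O)N(C)C` share much of their structure, but the difference between their two cores is not broken down here. In a physicochemical assay for solubility, in phosphate buffer, measured as kinetic solubility, at pH 7.4, tested at 250 uM (on this read-out higher numbers stand for higher solubility and lower numbers for lower solubility), compound 1 gives 53000 nM and compound 2 gives 243000 nM; compound 1 stands lowest of the three measured compounds, and its gap to compound 2 lies beyond the scatter. Compound 3 `CN(C)S(=O)(=O)c1cc(C(=O)O)ccc1NCCCCCC(F)(F)F` is made from compound 2 by one change, (trifluoromethyl in place of methyl on a saturated chain carbon, five bonds along the chain from a nitrogen on an aromatic ring). In this assay compound 3 gives 249000 nM, and the step of a 1.0-fold higher number from compound 2 to compound 3 (0.01 log units; within the scatter) means the two values cannot be told apart.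

Compound 4 `CNS(=O)(=O)c1cc(C(=O)O)ccc1NCCCCCCCC(F)(F)F` has not yet been measured. It differs from compound 1 by trifluoromethyl in place of methyl on a saturated chain carbon, seven bonds along the chain from a nitrogen on an aromatic ring. Among the compounds with values here, this is the same kind of change as the one from compound 2 to compound 3, but not the same: there the new group sits five bonds along the chain from a nitrogen on an aromatic ring, here seven bonds along. Within the data shown here, the earlier step of a 1.0-fold higher number from compound 2 to compound 3 (0.01 log units; within the scatter) is the one guide available, and it shows no movement. Compound 4 is therefore expected to show a step of about a 1.0-fold higher number from compound 1 to compound 4 (0.02 log units; within the scatter) in this assay. Among the measured compounds shown here, with only one prior example, and that at a different place on the chain, the range is kept wide. Compound 4 is estimated at 55000 nM, expected to fall between 25000 nM and 120000 nM.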

Compound 4, solubility: 242000 nM
For compound 4 the middle estimate is 4.4-fold (0.64 log units) below the measured one, and the stated range ends below it.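

On the core of compound 1, trifluoromethyl in place of methyl, seven bonds along the chain from a nitrogen on an aromatic ring, goes with a 4.6-fold higher number from compound 1 to compound 4 (0.66 log units; beyond the scatter) in this assay, whereas five bonds along the chain on the other core, the same kind of swap gave a 1.0-fold higher number from compound 2 to compound 3 (0.01 log units; within the scatter), so the change did not carry from one core to the other with the same size. Compound 2 already gives 243000 nM, close to the concentration at which the test was run, so the earlier step had little room to show a higher number and is a weak guide for a compound starting as low as compound 1. The two pairs differ both in core and in the place of the swap, so these results cannot say which of the two accounts for the different steps, and no measurement offered here explains either step.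

An octyl chain on the core of compound 2 and a hexyl chain on the core of compound 1, each with and without the trifluoromethyl end, would separate the effect of the core from that of the chain. Also open, going by these compounds, is whether the same swap on a shorter butyl chain, or with an amide in place of the carboxylic acid, would give a step of similar size.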